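This account rests on a few compounds, and the source may have more. Where it says the series, first, only, none or still open, it means among the compounds named here.

In a functional assay on HeLa cells (Homo sapiens) for cytotoxicity, read by MTT assay, with a stated time of 48 h (on this read-out lower numbers stand for stronger inhibition and higher numbers for weaker inhibition), three compounds of the series have numbers. Compound 1 (`COc1cc(/C=C/c2ccc(C)cc2)c(-c2ccccc2)c(OC)c1OC`) gives 45000 nM, compound 2 (`C=C(c1ccc(OC)cc1)c1cc(OC)c(OC)c(OC)c1-c1ccccc1`) gives 11000 nM, and compound 3 (`C=C(c1ccc(C)cc1)c1cc(OC)c(OC)c(OC)c1-c1ccccc1`) gives 28000 nM. Compound 3 therefore sits with the higher numbers of this small set. The comparison with one neighbour, a 1.6-fold lower number from compound 1 to compound 3 (0.21 log units; within the scatter), does not separate the two compounds, whereas the other, a 2.5-fold higher number from compound 2 to compound 3 (0.41 log units; beyond the scatter), is a modest step.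

Compound 4 (`C=C(c1ccc(Cl)cc1)c1cc(OC)c(OC)c(OC)c1-c1ccccc1`) keeps the rest of compound 3 and changes one group: chloro in place of methyl on an aromatic carbon. This is chloro in place of methyl on an aromatic carbon, para to a large group, so 4-methylphenyl becomes 4-chlorophenyl. Going by the values given here, no measured step involves chloro. The closest evidence is the change on that same carbon, methyl in place of methoxy, seen in a 2.5-fold higher number from compound 2 to compound 3 (0.41 log units; beyond the scatter). That one step is modest and involves a different pair of groups, so it gives no firm direction for the new change. No step beyond the scatter is expected in this assay, with only a slight lean towards a lower number. The estimated step is a 1.3-fold lower number from compound 3 to compound 4 (0.10 log units; within the scatter). For compound 4 the expected value is 22000 nM, with an estimated range of 10000 nM to 48000 nM.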

Compound 4, half-maximal inhibitory concentration: 34000 nM
Compound 4: the middle estimate sits 1.5-fold (0.19 log units) below what was measured; measured number inside the range.
By their numbers in this assay, from the lowest: compound 2; then compounds 3, 4 and 1 (each within the scatter of the next).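

In this assay, chloro in place of methyl on this aromatic carbon does not separate the two compounds (a 1.2-fold higher number from compound 3 to compound 4 (0.08 log units; within the scatter)), so 4-methylphenyl and 4-chlorophenyl cannot be told apart here. Chloro in place of methoxy on the same carbon gives a modest step (a 3.1-fold higher number from compound 2 to compound 4 (0.49 log units; beyond the scatter)), similar to the earlier one with methyl (a 2.5-fold higher number from compound 2 to compound 3 (0.41 log units; beyond the scatter)); among compounds 2, 3 and 4, only the methoxy compound, compound 2, stands apart, with the lower number. The 1-(4-chlorophenyl)ethenyl compound also cannot be told apart from the 2-(4-methylphenyl)ethenyl compound (a 1.3-fold lower number from compound 1 to compound 4 (0.12 log units; within the scatter)), and no supporting data bear on the reason for any of these readings.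

Open, on these data alone, is how an amine, a hydroxyl or a carboxylic acid on this carbon would read against methoxy in this assay. Also open, as far as these compounds go, is how a 2-(4-methoxyphenyl)ethenyl group would read on the shared core, which would show whether the methoxy compound keeps its lower number with that arrangement of the ethenyl group.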